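A few compounds are considered here, and "the series" means these few. Any claim that something is new, unique, unknown or untested is made for them only; others in the source may bear on it.

For the measured compounds named here, compound 2 `O=C(Nn1c(CCc2ccccc2)nc2c(-c3ccc(Cl)cc3)n[nH]c2c1=O)c1ccccc1` in a functional assay on HT-29 cells (Homo sapiens) for inhibition, read by MTT assay, with a stated time of 2 days (a higher number here means a weaker inhibitor of growth, a lower number a stronger inhibitor of growth), gives 23400 nM, the highest of the two numbers so far, though only within the scatter of compound 1 `COc1cccc(-c2nc3c(-c4ccc(Cl)cc4)n[nH]c3c(=O)n2NC(=O)c2ccccc2)c1`, which gives 20400 nM. Going by the values given here, the single measured step, a 1.1-fold higher number from compound 1 to compound 2 (0.06 log units; within the scatter), stayed within the scatter. Compound 3 `O=C(Nn1c(CCC2CCCC2)nc2c(-c3ccc(Cl)cc3)n[nH]c2c1=O)c1ccccc1` differs from compound 2 by cyclopentyl in place of phenyl on a saturated chain carbon, two bonds along the chain from an aromatic carbon. Among the compounds with values here, no measured step touches this place, and the one step seen moved the number little. In this assay the step from compound 2 to compound 3 is expected to be a 1.1-fold higher number from compound 2 to compound 3 (0.03 log units; within the scatter), nothing beyond the scatter. Compound 3 is expected to give about 25000 nM, between 10000 nM and 60000 nM.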

Compound 3, concentration for 50% growth inhibition: 1800 nM
Estimate against measurement, compound 3: 14-fold (1.14 log units) above; the whole stated range lies above it.
By their numbers in this assay, from the lowest: compound 3; then compounds 1 and 2 (each within the scatter of the next).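

Cyclopentyl in place of phenyl gives a 13-fold lower number from compound 2 to compound 3 (1.11 log units; beyond the scatter) in this assay and shows that the end of this chain can strongly change the number, which the earlier step did not reveal. Replacing 3-methoxyphenyl with 2-cyclopentylethyl gives an 11-fold lower number from compound 1 to compound 3 (1.05 log units; beyond the scatter) as well, so among these compounds the lower number comes only with the non-aromatic ring. Nothing measured here says why the number falls.

Open, going by these compounds, is whether cyclohexyl, cyclopropyl or an open butyl chain at this place would give a similar number. Also open, on these data alone, is how a ring carrying an amine, such as piperidine, would behave.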